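Replacing a Methylphenyl Ring with Pyridyl: What to Expect

The source may hold more compounds than are shown below. What is called first, only, known or untested is meant among the compounds shown, and "the series" means these compounds.

Measured so far:
Compound 1 `CC1=C(/C=C/C(=O)/C=C/c2ccccc2Cl)C(C)(C)CCC1`: 13700 nM
Compound 2 `CC1=C(/C=C/C(=O)/C=C/c2ccccc2C)C(C)(C)CCC1`: 63200 nM

In a functional assay on IMR-32 cells (Homo sapiens) for cytotoxicity, read by sulforhodamine B assay, with a stated time of 48 h (a higher number here means a weaker inhibitor, a lower number a stronger inhibitor), compound 1 gives 13700 nM, while compound 2 gives 63200 nM, the highest of the two numbers; the step between them was a 4.6-fold higher number from compound 1 to compound 2 (0.66 log units; beyond the scatter). Compound 3 `CC1=C(/C=C/C(=O)/C=C/c2cccnc2)C(C)(C)CCC1` differs from compound 2 by pyridin-3-yl in place of 2-methylphenyl on a double-bonded chain carbon bound to a double-bonded chain carbon. Among the compounds with values here, the only measured step altered a small substituent on the ring, not the ring itself, so no measured step bears directly on this exchange. Without such a precedent, compound 3 is expected to land near compound 2, a step of a 1.8-fold lower number from compound 2 to compound 3 (0.26 log units; within the scatter). Compound 3 is therefore estimated at 35000 nM, within a wide range from 8000 nM to 150000 nM.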

Compound 3, half-maximal inhibitory concentration: 25300 nM
Compound 3: the middle estimate sits 1.4-fold (0.14 log units) above what was measured; the measured number falls inside the stated range.
By their numbers in this assay, from the lowest: compounds 1 and 3 (each within the scatter of the next); then compound 2.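

In this assay, this place tolerates exchange of the whole ring, not only of a small substituent on it: pyridin-3-yl in place of 2-methylphenyl gives a modest step (a 2.5-fold lower number from compound 2 to compound 3 (0.40 log units; beyond the scatter)). Pyridin-3-yl in place of 2-chlorophenyl stays within the scatter (a 1.8-fold higher number from compound 1 to compound 3 (0.27 log units; within the scatter)), so compound 1 and compound 3 cannot be told apart. Nothing shown here explains either step.

Still open, on these data alone, is how pyridin-2-yl or pyridin-4-yl would behave at this place, and what an amine or a carboxylic acid on the ring would do.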